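A few compounds are considered here, and "the series" means these few. Any claim that something is new, unique, unknown or untested is made for them only; others in the source may bear on it.

In an ADME assay for pharmacokinetics (a higher number here means that the compound lasts longer, a lower number that the compound disappears faster), compound 2 (`CO[C@H]1C(=O)N2C(C(=O)N(C)CC(=O)O)=C(CSc3nc(=O)c(=O)[nH]n3C)CS(=O)(=O)[C@H]12`) gives 22 h and compound 1 (`CO[C@H]1C(=O)N2C(C(=O)N3CCCC3)=C(COC(C)=O)CS(=O)(=O)[C@H]12`) gives 16 h, two values within the scatter of each other. Compound 3 (`CO[C@H]1C(=O)N2C(C(=O)N3CCCC3)=C(CSc3nc(=O)c(=O)[nH]n3C)CS(=O)(=O)[C@H]12`) keeps the rest of compound 2 but carries pyrrolidin-1-yl in place of (carboxymethyl)(methyl)amino on a carbonyl carbon. Among the compounds with values here, compound 1 also carries pyrrolidin-1-yl there, but the two measured compounds differ in more than one place, so no measured step isolates this change. No step beyond the scatter is expected in this assay. The expected step is a 1.2-fold lower number from compound 2 to compound 3 (0.09 log units; within the scatter). For compound 3 the estimated half-life is 18 h, with an expected range of 8 h to 40 h.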

Compound 3, half-life: 20 h
The estimate for compound 3 lay 1.1-fold (0.05 log units) below the measured number; low and high end bracket the measured number.
By their numbers in this assay, from the lowest: compounds 1, 3 and 2 (each within the scatter of the next).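

In this assay the swap of pyrrolidin-1-yl for (carboxymethyl)(methyl)amino on a carbonyl carbon can now be read on its own, and it stays within the scatter (a 1.1-fold lower number from compound 2 to compound 3 (0.04 log units; within the scatter)). The group with the six-membered aromatic ring, in place of the group without a ring on the saturated chain carbon, can also be read on its own and likewise stays within the scatter (a 1.3-fold higher number from compound 1 to compound 3 (0.10 log units; within the scatter)). No evidence is available to explain either result. On these data alone, whether a piperidin-1-yl or dimethylamino group on that carbonyl carbon would also stay within the scatter remains open. So does the outcome of a longer chain carrying the carboxylic acid.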